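Replacing a Carboxy Group with Fluoro on the Aryl Ring

The source may report more compounds than this note shows. Statements on the series, on what has been measured and on what is new or still open speak of the compounds shown alone.

Of the compounds shown here, two of a shared core have been tested in a functional assay on IMR-32 cells for inhibition of Voltage-dependent N-type calcium channel subunit alpha-1B (Homo sapiens), read by calcium flux; a higher number here means a weaker inhibitor, a lower number a stronger inhibitor. Compound 1 `CC1=NC(C)=C(C(=O)O)C(c2ccccc2)/C1=C(\O)OC/C=C/c1ccccc1` gives 2000 nM in this assay. Compound 2 `CC1=NC(C)=C(C(=O)O)C(c2cccc(C(=O)O)c2)/C1=C(\O)OC/C=C/c1ccccc1`, which carries a carboxy group on its phenyl ring, gives 37000 nM in this assay. For the measured compounds named here, the single measured step, a 19-fold higher number from compound 1 to compound 2 (1.27 log units; beyond the scatter), is large and lies beyond the scatter, so compound 2 stands as the higher of the two numbers, and the carboxy group on the aromatic carbon is tied to a much weaker result.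

Compound 3 `CC1=NC(C)=C(C(=O)O)C(c2cccc(F)c2)/C1=C(\O)OC/C=C/c1ccccc1` differs from compound 2 in one place: fluoro in place of carboxy on an aromatic carbon. Going by the values given here, the only step that bears on this change is the one from compound 1 to compound 2, which undid nothing but added the carboxy group. Taking the carboxy group away again, and putting a single fluorine atom in its place meta to a large group, is expected to move the number back toward that of compound 1. The expected step is therefore a 15-fold lower number from compound 2 to compound 3 (1.17 log units; beyond the scatter). Compound 3 is estimated to give about 2500 nM in this assay, within a range of 700 nM to 9000 nM.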

Compound 3, half-maximal inhibitory concentration: 1300 nM
For compound 3 the middle estimate is 1.9-fold (0.28 log units) above the measured one, and the stated range covers the measured number.
By their numbers in this assay, from the lowest: compounds 3 and 1 (each within the scatter of the next); then compound 2.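

In this assay, the exchange of 3-carboxyphenyl for 3-fluorophenyl gives a 28-fold lower number from compound 2 to compound 3 (1.45 log units; beyond the scatter) and so shows that the weak number of compound 2 does not come with every substituent on this aromatic carbon. Fluoro in place of hydrogen on that same carbon gives a 1.5-fold lower number from compound 1 to compound 3 (0.19 log units; within the scatter) and so leaves compound 3 level with compound 1 in this assay, which means that, among these three compounds, only the carboxy group goes with a large step at this place. The compounds therefore show that this place accepts one substituent with no readable change while another goes with a much weaker inhibitor, but nothing at hand explains the gap between fluoro and carboxy.

On these data alone, whether the weak number follows the carboxy group alone, or also a methyl ester, an amine or a hydroxy group at this place, remains open. So does whether chloro or methyl would stay level with hydrogen here as fluoro does, and whether fluoro on another carbon of the same aromatic ring would read the same way.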